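Trifluoromethylphenyl amide replaces furan on the shared core

The source may report more compounds than this note shows. Statements on the series, on what has been measured and on what is new or still open speak of the compounds shown alone.

Of the compounds shown here, two of one series have been measured in an assay on CHO cells for displacement of a labelled ligand from adenosine receptor A3 (Homo sapiens), read by scintillation counting; on this read-out lower numbers stand for stronger inhibition and higher numbers for weaker inhibition. Compound 1 `O=C(Nc1nc(-c2ccccc2)nc2c1nnn2Cc1ccccc1)c1ccccc1C(F)(F)F` gives 560 nM, and compound 2 `O=C(Nc1nc(-c2ccccc2)nc2c1nnn2Cc1ccccc1)c1ccoc1` gives 1640 nM. Within the data shown here, the only step between measured compounds, a 2.9-fold higher number from compound 1 to compound 2 (0.47 log units; beyond the scatter), replaces 2-(trifluoromethyl)phenyl with furan-3-yl on a carbonyl carbon. Compound 2 therefore stands at the highest of the two numbers, its nearest neighbour being compound 1 at a lower number beyond the scatter.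

Compound 3 `O=C(Nc1nc(-c2ccccc2)nc2c1nnn2Cc1ccccc1)c1ccc(C(F)(F)F)cc1` has not yet been measured in this assay. It differs from compound 2 in one place: 4-(trifluoromethyl)phenyl in place of furan-3-yl on a carbonyl carbon. This change is close to the reverse of the measured step, since it again puts a trifluoromethyl-bearing phenyl ring on the carbonyl carbon in place of the furan, though the trifluoromethyl group now sits on the 4-(trifluoromethyl)phenyl ring rather than the 2-(trifluoromethyl)phenyl ring of compound 1. The measured step of a 2.9-fold higher number from compound 1 to compound 2 (0.47 log units; beyond the scatter) is modest, so a modest step in the opposite direction is expected, back toward the number of compound 1. For compound 3 the estimated step is a 2.3-fold lower number from compound 2 to compound 3 (0.37 log units; beyond the scatter), and its expected value is 700 nM, with a range from 250 nM to 2000 nM.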

Compound 3, inhibition constant: 4210 nM
Compound 3: the middle estimate sits 6.0-fold (0.78 log units) below what was measured; measured number outside the range, above it.
By their numbers in this assay, from the lowest: compound 1; then compound 2; then compound 3.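

In this assay the result shows that a trifluoromethyl-bearing phenyl ring on the carbonyl carbon does not by itself go with the lower number: with 4-(trifluoromethyl)phenyl in place of 2-(trifluoromethyl)phenyl the change is a 7.5-fold higher number from compound 1 to compound 3 (0.88 log units; beyond the scatter) and is the largest step among the three compounds. Furan-3-yl now falls in the middle rather than at the top, and the new step is a 2.6-fold higher number from compound 2 to compound 3 (0.41 log units; beyond the scatter) in the opposite direction from the one that compound 1 shows against compound 2, so replacing the furan with such a ring can move the number either way at this position. Nothing available here accounts for the gap between the two trifluoromethyl-bearing rings.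

The compounds shown leave open whether the high number of compound 3 goes with the trifluoromethyl group itself or with the phenyl ring that carries it, a question that a plain phenyl ring or a 4-methoxyphenyl ring on the carbonyl carbon would address. They also leave open whether the same order holds when the benzyl group on the shared core gives way to a longer chain or an amine.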